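A few compounds are considered here, and "the series" means these few. Any claim that something is new, unique, unknown or untested is made for them only; others in the source may bear on it.

In a functional assay on DU-145 cells (Homo sapiens) for antiproliferative activity, read by WST assay, with a stated time of 3 days (a higher number here means a weaker inhibitor, a lower number a stronger inhibitor), compound 1 `CCCCCCOc1c(-c2cc(OC)c(OC)c(OC)c2)oc2ccccc2c1=O`, with a hexyl group on the oxygen, gives > 50000 nM, which is a limit of the assay and not a number. Compound 2 `CCC(C)Oc1c(-c2cc(OC)c(OC)c(OC)c2)oc2ccccc2c1=O`, with sec-butyl on that oxygen, gives > 50000 nM, also a limit. Going by the values given here, compound 3 `CCN(CC)CCCCCOc1c(-c2cc(OC)c(OC)c(OC)c2)oc2ccccc2c1=O`, carrying 5-(diethylamino)pentyl there, gives 33400 nM, the only true number among the three.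

Compound 4 `CCCCCN(CCCCC)CCCCCOc1c(-c2cc(OC)c(OC)c(OC)c2)oc2ccccc2c1=O` differs from compound 3 at one place: dipentylamino in place of diethylamino on a saturated chain carbon, five bonds along the chain from an oxygen on an aromatic ring. In words, dipentylamino stands in place of diethylamino on a saturated chain carbon, five bonds along the chain from an oxygen on an aromatic ring.

Among the compounds with values here, two measured steps bear on this change: an at least 1.4-fold lower number from compound 1 to compound 3 (0.17 log units; that floor lies within the scatter), and an at least 1.4-fold lower number from compound 2 to compound 3 (0.17 log units; that floor lies within the scatter). Both are only floors within the scatter, and both rest on (the limit of > 50000 nM in this assay, at which 2 of the 3 values shown sit). The remaining step, a step that the two limits leave unreadable from compound 1 to compound 2, offers no readable size. Within the data shown here, no measured step varies the groups on the amine nitrogen, so the expectation is loose: a modest move towards a lower number in this assay, in the direction of those two floors.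

The expected step is a 2.2-fold lower number from compound 3 to compound 4 (0.35 log units; beyond the scatter). For compound 4 the estimated value is 15000 nM, with an expected range from 4000 nM to 50000 nM.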

Compound 4, half-maximal inhibitory concentration: 11700 nM
Compound 4: the middle estimate sits 1.3-fold (0.11 log units) above what was measured, and the stated range covers the measured number.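

In this assay, going by these compounds alone, dipentylamino in place of diethylamino gives a 2.9-fold lower number from compound 3 to compound 4 (0.46 log units; beyond the scatter), so the groups on the amine nitrogen now have a measured step of their own, and it is the first readable step in this set that lies beyond the scatter. Against the hexyl group of compound 1, the 5-(dipentylamino)pentyl group gives an at least 4.2-fold lower number from compound 1 to compound 4 (0.63 log units; beyond the scatter), which also clears the scatter, whereas the floors set by compound 3 against compound 1 and compound 2 did not. That second step is a floor and not a measured size, since it starts from a limit of the assay: the limit of > 50000 nM in this assay, at which 2 of the 4 values shown sit.

With only diethylamino and dipentylamino to compare, the compounds shown leave open whether the number falls steadily as the chains on the nitrogen lengthen, or whether dipropylamino, dihexylamino or a ring amine such as piperidine would break that line. Also open, from the compounds shown here alone, is what a butyl or hexyl chain on the oxygen, ending in the same dipentylamino, would give.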